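The source may report more compounds than this note shows. Statements on the series, on what has been measured and on what is new or still open speak of the compounds shown alone.

Compound 1 `O=C(O)c1cn(C2CC2)c2cc(N3CCN(Cn4nc(-c5cccc(O)c5)n(-c5ccccc5)c4=S)CC3)c(F)cc2c1=O` is the starting point here. In an ADME assay on HEK293 cells (Homo sapiens) for cytotoxicity, read by MTT assay, with a stated time of 72 h (on this read-out lower numbers stand for an effect already at smaller amounts and higher numbers for an effect only at larger amounts of compound), compound 1 gives 140000 nM. Compound 2 `O=C(O)c1cn(C2CC2)c2cc(N3CCN(Cn4nc(-c5cccc(O)c5)n(Cc5ccc(F)cc5)c4=S)CC3)c(F)cc2c1=O` differs from it only in carrying a 4-fluorobenzyl in place of phenyl on an aromatic nitrogen, and in this assay compound 2 gives 69500 nM. Among the compounds with values here, the step of a 2.0-fold lower number from compound 1 to compound 2 (0.30 log units; within the scatter) is the only comparison measured so far. The two numbers lie within the scatter of one another, so neither compound can be placed ahead of the other on this read-out; compound 2 has no measured neighbour that is clearly apart from it.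

Compound 3 `COc1ccc(Cn2c(-c3cccc(O)c3)nn(CN3CCN(c4cc5c(cc4F)c(=O)c(C(=O)O)cn5C4CC4)CC3)c2=S)cc1` is not yet measured. It differs from compound 2 by methoxy in place of fluoro on an aromatic carbon. Within the data shown here, no measured step touches this part of the molecule: the one step available, from compound 1 to compound 2, changed the group on the aromatic nitrogen as a whole and stayed within the scatter. On that thin basis, a step beyond the scatter is not expected for the smaller exchange in compound 3, so the expected step is a 1.0-fold higher number from compound 2 to compound 3 (0.00 log units; within the scatter). In this assay compound 3 is therefore estimated at 70000 nM, with a range from 30000 nM to 160000 nM.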

Compound 3, half-maximal effective concentration: 62900 nM
Compound 3: middle estimate off by 1.1-fold (0.05 log units), on the high side, and the stated range covers the measured number.
By their numbers in this assay, from the lowest: compounds 3, 2 and 1 (each within the scatter of the next, the first and the last beyond it).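

In this assay, replacing 4-fluorobenzyl with 4-methoxybenzyl gives a 1.1-fold lower number from compound 2 to compound 3 (0.04 log units; within the scatter), so at this place, para to a large group, the swap of fluoro for methoxy, with its added heavy atom and hydrogen-bond acceptor, leaves the number within the scatter. Within the data shown here, measured against the phenyl of compound 1, the 4-methoxybenzyl group gives a 2.2-fold lower number from compound 1 to compound 3 (0.35 log units; beyond the scatter), the first step in this set that clears the scatter, though only modestly, while compound 2 remains within the scatter of both other compounds and the two benzyl compounds cannot be ranked. Nothing available explains either step.

The compounds shown leave open how much of the step from phenyl comes from the benzyl group itself and how much from its methoxy substituent, a question that plain benzyl, with no substituent on its ring, would address. They also leave open whether a more different group at the same para place, such as an amine or a carboxylic acid, would move the number beyond the scatter, as neither fluoro nor methoxy did.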